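Swapping Phenyl for Thiophen-2-yl in an Inactive Compound

A few compounds are considered here, and "the series" means these few. Any claim that something is new, unique, unknown or untested is made for them only; others in the source may bear on it.

Compound 1 (`COc1cc(/C=C/C(=O)/C=C/c2ccccc2)ccc1OCc1cn(CCCCOc2cc(=O)oc3ccccc23)nn1`) offers no number to build on: in a functional assay on PC-3 cells (Homo sapiens) for inhibition, read by sulforhodamine B assay, with a stated time of 48 h, tested at 50 uM (on this read-out higher numbers stand for more inhibition of growth at the one concentration tested and lower numbers for less inhibition of growth), compound 1 gives "not active" (no number reported) as its result. Compound 3 (`COc1ccccc1/C=C/C(=O)/C=C/c1ccc(OCc2cn(CCCCCOc3cc(=O)oc4ccccc34)nn2)c(OC)c1`), a close relative, gives the same kind of entry ("not active" (no number reported)) in this test. Only compound 2 (`COc1cccc(/C=C/C(=O)/C=C/c2ccc(OCc3cn(CCOc4cc(=O)oc5ccccc45)nn3)c(OC)c2)c1`) has a figure, at 13% on the same scale. Together, these three results mark out a family with little or no growth inhibition at the single concentration tested.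

Compound 4 (`COc1cc(/C=C/C(=O)/C=C/c2cccs2)ccc1OCc1cn(CCCCOc2cc(=O)oc3ccccc23)nn1`) has not yet been measured. It keeps the core of compound 1 and makes one change (thiophen-2-yl in place of phenyl on a double-bonded chain carbon bound to a double-bonded chain carbon): thiophen-2-yl in place of phenyl on a double-bonded chain carbon bound to a double-bonded chain carbon. Within the data shown here, no measured pair here shows what this swap does. In this assay I therefore expect no step beyond the usual scatter, and I favour neither direction. Compound 4 may well also be reported without a number. If a number is reported, the estimate for compound 4 is 8% (expected range 0% to 22%).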

Compound 4, percent growth inhibition at one concentration: "not active" (no number reported)
For compound 4 the study gives words and no number, and the estimate cannot be compared.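

Compound 1 and compound 4 both come without a number in this assay and so no step can be read for thiophen-2-yl in place of phenyl. The compounds shown leave open whether this swap changes growth inhibition at all. No measurement here bears on either result.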